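A few compounds are considered here, and "the series" means these few. Any claim that something is new, unique, unknown or untested is made for them only; others in the source may bear on it.

Values in an ADME assay on HEK293 cells (Homo sapiens) for inhibition, read by MTT assay, with a stated time of 3 days; on this read-out higher numbers stand for weaker inhibition and lower numbers for stronger inhibition:
Compound 1 `COc1ccc(COc2cc(/C=C\c3cc(OC)c(OC)c(OC)c3)ccc2OC)cc1`: 64000 nM
Compound 2 `COc1ccccc1/C=C/CCCOc1cc(/C=C\c2cc(OC)c(OC)c(OC)c2)ccc1OC`: > 400000 nM
Compound 3 `COCOc1cccc(/C=C/CCCOc2cc(/C=C\c3cc(OC)c(OC)c(OC)c3)ccc2OC)c1`: 30000 nM

Only two of these entries are true numbers, and compound 3 holds the lower one at 30000 nM. The entry for compound 2, > 400000 nM, is a limit of the assay and not a number.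

The next candidate is compound 4 `COc1ccc(/C=C\c2cc(OC)c(OC)c(OC)c2)cc1OCCC/C=C/c1ccc(Br)cc1`, which has not yet been measured. Its difference from compound 3 is 4-bromophenyl in place of 3-(methoxymethoxy)phenyl on a double-bonded chain carbon bound to a double-bonded chain carbon. In other words, 4-bromophenyl takes the place of 3-(methoxymethoxy)phenyl on a double-bonded chain carbon bound to a double-bonded chain carbon.

The most relevant evidence is an at least 13-fold lower number from compound 2 to compound 3 (1.12 log units; beyond the scatter). This large step came from a swap at this same place, so a change here can move the result in this assay a long way. The other measured step, an at least 6.2-fold higher number from compound 1 to compound 2 (0.79 log units; beyond the scatter), is less direct, since it replaced a larger stretch of the side group. Among the compounds with values here, neither step involves 4-bromophenyl, and only two groups have been compared at this place. The low number of compound 3, 30000 nM, is therefore more likely to rise than to fall, and a modest move is the reasonable expectation.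

The expected change is a 2.3-fold higher number from compound 3 to compound 4 (0.37 log units; beyond the scatter). For compound 4 the estimated value is 70000 nM, with an expected range of 15000 nM to 300000 nM.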

Compound 4, half-maximal inhibitory concentration: 55000 nM
For compound 4 the middle estimate is 1.3-fold (0.10 log units) above the measured one; the range from low to high includes it.
By their numbers in this assay, from the lowest: compounds 3, 4 and 1 (each within the scatter of the next, the first and the last beyond it). At a limit, above all of these: compound 2.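

In this assay the swap at this place gives a 1.8-fold higher number from compound 3 to compound 4 (0.26 log units; within the scatter) and so 4-bromophenyl and 3-(methoxymethoxy)phenyl cannot be told apart, although the first has 0 hydrogen-bond acceptors and the second has 2. Compound 4 also cannot be told apart from compound 1, with a 1.2-fold lower number from compound 1 to compound 4 (0.07 log units; within the scatter) and thus a result within the scatter for two quite different side groups. The earlier compounds left open whether compound 3 was a lone exception to compound 2, but an at least 7.2-fold lower number from compound 2 to compound 4 (0.86 log units; beyond the scatter) now shows a second group at this place standing clearly apart from 2-methoxyphenyl, and the entry for compound 2 is a limit of the assay and not a number: the limit of > 400000 nM in this assay, at which 1 of the 4 values shown sits.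

From the compounds shown here alone, whether the kind of substituent on the phenyl ring or its place on that ring separates compound 2 from compounds 3 and 4 stays open; the three groups differ in both. How a plain phenyl, or a group with no aromatic ring such as a carboxylic acid or an amine, would read at this place is also unknown.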